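Series notes: amide cap change from compound 2 to compound 4

The source may hold more compounds than are shown below. What is called first, only, known or untested is meant among the compounds shown, and "the series" means these compounds.

The shared core carries an amide on the aryl group; the cap varies. Compound 1 `O=C(Nc1cccc(-c2oc3cc(-c4ccc(F)cc4)ccc3c(=O)c2O)c1)c1ccc(Cl)cc1` gives 4030 nM in a functional assay on HCC1937 cells (Homo sapiens) for antiproliferative activity, read by CCK-8 assay, with a stated time of 72 h; a higher number here means a weaker inhibitor, a lower number a stronger inhibitor. Compound 2 `O=C(Nc1cccc(-c2oc3cc(-c4ccc(F)cc4)ccc3c(=O)c2O)c1)c1ccc(Br)cc1` gives 8630 nM in this assay, and compound 3 `CCc1ccc(C(=O)Nc2cccc(-c3oc4cc(-c5ccc(F)cc5)ccc4c(=O)c3O)c2)cc1` gives 13200 nM. Among these three numbers compound 2 lies between the others: the step of a 2.1-fold higher number from compound 1 to compound 2 (0.33 log units; beyond the scatter) is beyond the scatter, whereas the step of a 1.5-fold higher number from compound 2 to compound 3 (0.18 log units; within the scatter) is within it, so compound 2 and compound 3 cannot be ordered. The step of a 3.3-fold higher number from compound 1 to compound 3 (0.52 log units; beyond the scatter) is the widest of the three.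

Compound 4 `COc1cc(OC)cc(C(=O)Nc2cccc(-c3oc4cc(-c5ccc(F)cc5)ccc4c(=O)c3O)c2)c1` differs from compound 2 by 3,5-dimethoxyphenyl in place of 4-bromophenyl on a carbonyl carbon. Among the measured compounds shown here, no measured step involves a methoxy group or a 3,5-disubstituted cap; the three steps only show that exchanging one para-type substituent for another moved the number across a modest span, with the halogen caps of compound 1 and compound 2 at the lower end. The expected step of a 1.3-fold higher number from compound 2 to compound 4 (0.11 log units; within the scatter) is therefore small and uncertain in direction, with a slight lean to a higher number. For compound 4 the estimated value is 11000 nM, with a range from 4000 nM to 30000 nM.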

Compound 4, half-maximal inhibitory concentration: 6250 nM
Estimate against measurement, compound 4: 1.8-fold (0.25 log units) above; the range from low to high includes it.
By their numbers in this assay, from the lowest: compounds 1, 4, 2 and 3 (each within the scatter of the next, the first and the last beyond it).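

Among the compounds shown here, at this place on a carbonyl carbon, 3,5-dimethoxyphenyl is the first cap that lacks a 4-substituent and carries hydrogen-bond acceptors, yet in this assay it cannot be separated from either halogen-bearing cap: a 1.4-fold lower number from compound 2 to compound 4 (0.14 log units; within the scatter) and a 1.6-fold higher number from compound 1 to compound 4 (0.19 log units; within the scatter) are both read as lying within the scatter. For the compounds shown here, it separates only from the 4-ethylphenyl cap, with a 2.1-fold lower number from compound 3 to compound 4 (0.32 log units; beyond the scatter) as the one step beyond the scatter, so a halogen on the cap is not required to stay clear of compound 3 in this small set. No measurement available here accounts for any of these steps.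

Going by these compounds, whether one methoxy group alone would read like the two of compound 4 remains open. Also open, on these data alone, is how the number responds to a cap bearing an amine or a carboxylic acid, or to a longer chain in place of the aromatic ring.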